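Trifluoromethyl for methyl on a benzamide-linked benzothiazole

The compounds below may be only part of what the source reports. "The series", "measured", "known", "first", "only" and "open" are said of these compounds alone.

Measured in a functional assay on MDA-MB-231 cells (Homo sapiens) for antiproliferative activity, read by sulforhodamine B assay; on this read-out lower numbers stand for stronger inhibition of growth and higher numbers for weaker inhibition of growth:
Compound 1 `O=C(Nc1cccc([N+](=O)[O-])c1)Nc1nc2ccc(F)cc2s1` gives 0.89 ug/mL.
Compound 2 `COc1ccc2sc(NC(=O)c3ccc(C)cc3)nc2c1` gives > 10 ug/mL, which is a limit of the assay and not a number.
Compound 3 `Cc1cc(C)c2sc(NC(=O)c3ccc(C#N)cc3)nc2c1` gives 0.48 ug/mL.

Compound 2 therefore stands at the limit of > 10 ug/mL in this assay, at which 1 of the 3 values shown sits, so its true growth inhibition is not pinned down. Compound 4 `COc1ccc2sc(NC(=O)c3ccc(C(F)(F)F)cc3)nc2c1` differs from compound 2 in one place: trifluoromethyl in place of methyl on an aromatic carbon, para to a large group. Among the measured compounds shown here, no measured pair isolates this change, so its effect is open. Compound 4 is expected to land near 6 ug/mL, within 1.5 ug/mL to 20 ug/mL. That estimate means an expected step of an at least 1.6-fold lower number from compound 2 to compound 4 (0.22 log units; that floor lies within the scatter) toward stronger inhibition, though it may again be reported only as a limit.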

Compound 4, concentration for 50% growth inhibition: > 10 ug/mL
Compound 4 gave a limit, no number (the forecaster's own chance of this, stated with the estimate: 40%); at least 1.6-fold (0.22 log units) between middle value and limit.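

Compound 2 and compound 4 both stop at a limit of the assay and not at a number, so no step can be read between them: the limit of > 10 ug/mL in this assay, at which 2 of the 4 values shown sit.

The compounds shown leave open whether trifluoromethyl in place of methyl on an aromatic carbon changes growth inhibition at all.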